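Moving from 4-fluorophenyl to 2-fluorophenyl on a shared core

This account rests on a few compounds, and the source may have more. Where it says the series, first, only, none or still open, it means among the compounds named here.

Measured in an ADME assay on MT4 cells (Homo sapiens) for cytotoxicity, read by MTT assay, with a stated time of 96 h; a higher number here means that more compound is tolerated, a lower number that less compound is tolerated:
Compound 1 `NS(=O)(=O)c1ccc(N2N=C(c3ccccc3)CC2c2ccccc2F)cc1`: 42000 nM
Compound 2 `NS(=O)(=O)c1ccc(N2N=C(c3ccc(Oc4ccccc4)cc3)CC2c2ccc(F)cc2)cc1`: 33000 nM

These two values lie within the usual scatter of repeated measurements, so compound 2 cannot be separated from compound 1 on these numbers. Going by the values given here, no two measured compounds differ in just one place, so no single structural change has yet been observed directly.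

Compound 3 `NS(=O)(=O)c1ccc(N2N=C(c3ccc(Oc4ccccc4)cc3)CC2c2ccccc2F)cc1` comes from compound 2 through one change: 2-fluorophenyl in place of 4-fluorophenyl on a saturated ring carbon. In words, 2-fluorophenyl stands in place of 4-fluorophenyl on a saturated ring carbon, and the rest of compound 2 stays the same.

Compound 1 carries the 2-fluorophenyl group and gives 42000 nM, while compound 2 carries the 4-fluorophenyl group and gives 33000 nM. With only these two values to go on, no step beyond the scatter is expected in this assay, and no direction can be called. The estimated step is a 1.1-fold higher number from compound 2 to compound 3 (0.03 log units; within the scatter). For compound 3 the estimated value is 35000 nM, with an expected range of 16000 nM to 70000 nM.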

Compound 3, half-maximal cytotoxic concentration: 36000 nM
Beside the measured number, compound 3's estimate is 1.0-fold (0.01 log units) below it, within the range that was stated.
By their numbers in this assay, from the lowest: compounds 2, 3 and 1 (each within the scatter of the next).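

In this assay, the swap of 4-fluorophenyl for 2-fluorophenyl on a saturated ring carbon can now be read directly, with the rest of the molecule held the same: the step is a 1.1-fold higher number from compound 2 to compound 3 (0.04 log units; within the scatter) and cannot be told apart from no change at all. The phenoxy group, in place of hydrogen on an aromatic carbon, can also now be read on its own, as a 1.2-fold lower number from compound 1 to compound 3 (0.07 log units; within the scatter) shows, and that step likewise stays inside the usual scatter, so on these three compounds neither change separates itself from the noise in how much compound the cells tolerate. No measurement among these results accounts for either outcome.

The compounds shown only compare two fluorophenyl groups at this saturated ring carbon, so it stays open whether a group of a different kind there, such as a phenyl ring carrying an amine or a carboxylic acid, would give a step beyond the scatter. The same question stands for the phenoxy place, where a longer chain could be set against hydrogen and phenoxy.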